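The source may report more compounds than this note shows. Statements on the series, on what has been measured and on what is new or still open speak of the compounds shown alone.

Working notes on the step to compound 4. Within the data shown here, in a functional assay on NCI-H1975 cells (Homo sapiens) for antiproliferative activity, read by CCK-8 assay, with a stated time of 72 h (a higher number here means a weaker inhibitor of growth, a lower number a stronger inhibitor of growth), compound 3 `CCC1C(=O)N(C)c2cnc(-n3ccc4cc(F)ccc43)nc2N1c1ccn(C)n1` gives 28600 nM, at the high end of the three numbers so far. Compound 1 `CCC1C(=O)N(C)c2cnc(-n3ccc4cc(C(=O)NC)ccc43)nc2N1c1ccn(C)n1` gives 35700 nM, within the scatter of compound 3. Compound 2 `CCCCNS(=O)(=O)c1ccc(Nc2ncc3c(n2)N(C2CCCC2)[C@H](CC)C(=O)N3C)cc1`, on a different core, gives 1610 nM, well apart from the other two.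

The next compound is compound 4 `CCCCNC(=O)c1ccc2c(ccn2-c2ncc3c(n2)N(c2ccn(C)n2)C(CC)C(=O)N3C)c1`, with butylcarbamoyl in place of fluoro on an aromatic carbon. Among the measured compounds shown here, one measured step bears on this change: a 1.2-fold lower number from compound 1 to compound 3 (0.10 log units; within the scatter), which swaps methylcarbamoyl for fluoro at the same carbon and stays within the scatter. For the measured compounds named here, no measurement yet separates butylcarbamoyl from methylcarbamoyl. Compound 2 differs in too many places to serve as a guide. No shift beyond the scatter is therefore expected in this assay, and the estimated change is a 1.4-fold lower number from compound 3 to compound 4 (0.16 log units; within the scatter). For compound 4 the estimate is 20000 nM, with an expected range of 6000 nM to 50000 nM.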

Compound 4, concentration for 50% growth inhibition: 12000 nM
For compound 4 the middle estimate is 1.7-fold (0.22 log units) above the measured one; the measured number falls inside the stated range.
By their numbers in this assay, from the lowest: compound 2; then compound 4; then compounds 3 and 1 (each within the scatter of the next).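

In this assay, butylcarbamoyl in place of fluoro gives a 2.4-fold lower number from compound 3 to compound 4 (0.38 log units; beyond the scatter), so this aromatic carbon, para to a fused ring, does respond to a change of group, which the swap between methylcarbamoyl and fluoro did not show. The difference between the two amides is also now measured: propyl in place of hydrogen on the saturated chain carbon bound to the amide-type nitrogen gives a 3.0-fold lower number from compound 1 to compound 4 (0.47 log units; beyond the scatter), so the chain on the amide matters here, although methylcarbamoyl and fluoro could not be told apart. No available data explain either step.

Butyl is the only chain here beyond methyl, so it remains open whether a longer chain, or an amine on the chain, would lower the number further. Also open, as far as these compounds go, is whether butylcarbamoyl at this carbon gives a similar step on other cores.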